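Chain-end cyclopentyl on the shared core: compound 3 expected

The source may hold more compounds than are shown below. What is called first, only, known or untested is meant among the compounds shown, and "the series" means these compounds.

Of the compounds shown here, two carrying the shared core have been measured in an assay on THP-1 cells for inhibition of nuclear factor NF-kappa-B complex (Homo sapiens), with stated times of 2 h and 16 h; a higher number here means a weaker inhibitor, a lower number a stronger inhibitor.

compound 1, `O=C(/C=C/c1ccc(O)cc1)c1c(O)cccc1OCC1CCCC1`: 13000 nM
compound 2, `CCCCOc1cccc(O)c1C(=O)/C=C/c1ccc(O)cc1`: > 30000 nM, a limit of the assay

Compound 2 stands at the limit of > 30000 nM in this assay, at which 1 of the 2 values shown sits, so only a limit is known for it. Among the measured compounds shown here, the one step between measured compounds runs an at least 2.3-fold higher number from compound 1 to compound 2 (0.36 log units; beyond the scatter), in which the cyclopentyl of compound 1 gives way to propyl; compound 2 is therefore the weaker of the two beyond the scatter. Compound 3, `O=C(/C=C/c1ccc(O)cc1)c1c(O)cccc1OCCC1CCCC1`, is not yet measured. It differs from compound 2 by cyclopentyl in place of ethyl on a saturated chain carbon, two bonds along the chain from an oxygen on an aromatic ring, which is the reverse kind of exchange, cut one bond further out along the chain. For the measured compounds named here, the only step that bears on it is an at least 2.3-fold higher number from compound 1 to compound 2 (0.36 log units; beyond the scatter), an at least modest loss on removing the cyclopentyl; restoring a cyclopentyl is expected to recover some of that, giving a step of an at least 2.0-fold lower number from compound 2 to compound 3 (0.30 log units; that floor lies within the scatter) back into the measurable range. Compound 3 is therefore estimated at 15000 nM in this assay, with a range from 5000 nM to 40000 nM, though a limit remains possible.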

Compound 3, half-maximal inhibitory concentration: 18000 nM
For compound 3 the middle estimate is 1.2-fold (0.08 log units) below the measured one; low and high end bracket the measured number.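

In this assay, the step of an at least 1.6-fold lower number from compound 2 to compound 3 (0.22 log units; that floor lies within the scatter) shows that a cyclopentyl further out along the chain still goes with a number inside the measurable range, which the earlier pair showed only for the cyclopentyl of compound 1. Only a floor can be given for that step, since the value of compound 2 is a limit of the assay and not a number: the limit of > 30000 nM in this assay, at which 1 of the 3 values shown sits. The step of a 1.4-fold higher number from compound 1 to compound 3 (0.14 log units; within the scatter) shows that cyclopentylmethyl and cyclopentyl on the saturated chain carbon bound to an oxygen on an aromatic ring cannot be told apart in this assay, so the exact placing of the ring along the chain makes no readable difference across these two compounds.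

The compounds shown leave open whether the ring itself matters or simply the larger number of chain carbons, which a longer open chain such as hexyl would separate. As far as these compounds go, it also remains open whether an amine or a carboxylic acid at the end of the chain would keep the number in the measurable range, or whether a larger ring such as cyclohexyl would move it.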